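The compounds below may be only part of what the source reports. "The series", "measured", "known", "first", "only" and "open" are said of these compounds alone.

Compound 1 `C=CS(=O)(=O)NCc1ccc(C(=O)Nc2ccc(C)c(Nc3nccc(-c4cccnc4)n3)c2)cc1`: 7710 nM
Compound 2 `C=CC(=O)NCc1cccc(C(=O)Nc2ccc(C)c(Nc3nccc(-c4cccnc4)n3)c2)c1`: > 10000 nM

The read-out throughout is an ADME assay on BaF3 cells (Mus musculus) for cytotoxicity, read by CellTiter-Glo and CCK-8 assay, with a stated time of 72 h; a higher number here means a weaker inhibitor of growth, a lower number a stronger inhibitor of growth. Compound 2 stands only at a limit of this assay, > 10000 nM, and has no number. Compound 3 `C=CC(=O)Nc1cccc(C(=O)Nc2ccc(C)c(Nc3nccc(-c4cccnc4)n3)c2)c1` differs from it by (vinylcarbonyl)amino in place of ((vinylcarbonyl)amino)methyl on an aromatic carbon. For the measured compounds named here, no measured step covers this change. Going by the values given here, the only guide is compound 1 at 7710 nM, the sole number. A modest at least 1.6-fold lower number from compound 2 to compound 3 (0.22 log units; that floor lies within the scatter) is expected, towards stronger inhibition of growth. The estimate for compound 3 is 6000 nM, with an expected range of 2000 nM to 10000 nM.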

Compound 3, concentration for 50% growth inhibition: 2480 nM
Beside the measured number, compound 3's estimate is 2.4-fold (0.38 log units) above it; the measured number falls inside the stated range.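

On this aromatic carbon, meta to a large group, (vinylcarbonyl)amino in place of ((vinylcarbonyl)amino)methyl gives in this assay an at least 4.0-fold lower number from compound 2 to compound 3 (0.60 log units; beyond the scatter), so growth inhibition responds to this change. That step is a floor and not a full size, because compound 2 stands at a limit of the assay: the limit of > 10000 nM in this assay, at which 1 of the 3 values shown sits.

As far as these compounds go, whether compound 3 needs the vinyl double bond for its growth inhibition stays open, and a propanoylamino group on the same carbon would test this. From the compounds shown here alone, the effect of a longer chain at this carbon also stays open.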